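The source may hold more compounds than are shown below. What is called first, only, known or untested is meant among the compounds shown, and "the series" means these compounds.

Measured so far in an assay on isolated protein for displacement of a labelled ligand from metabotropic glutamate receptor 5 (Homo sapiens), with a stated time of 60 min, tested at 1 uM; a lower number here means less inhibition, a higher number more inhibition at the concentration tested (going by the name of the read-out):
compound 1 `Cc1ccc2ncc(S(=O)(=O)c3ccc(F)cc3)c(N3CCC(C)CC3)c2c1`: 90%
compound 2 `Cc1ccc2ncc(S(=O)(=O)c3ccc(F)c(Cl)c3)c(N3CCC(C)CC3)c2c1`: 93%
compound 3 `CC1CCN(c2c(S(=O)(=O)c3ccc(F)c(Cl)c3)cnc3ccc(F)cc23)CC1`: 95%

In this assay compound 2 gives 93%, and the steps to its neighbours, a number 3 percentage points higher from compound 1 to compound 2 (within the scatter) and a number 2 percentage points higher from compound 2 to compound 3 (within the scatter), both lie within the scatter, so the three measured numbers sit level.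

Compound 4 `Cc1ccc2ncc(S(=O)(=O)c3ccc(C)c(F)c3)c(N3CCC(C)CC3)c2c1` is a new variant. The change from compound 2 is 3-fluoro-4-methylphenyl in place of 3-chloro-4-fluorophenyl on a sulfonyl sulfur. The step that bears on this part of the molecule is a number 3 percentage points higher from compound 1 to compound 2 (within the scatter), which altered the same ring on the sulfonyl sulfur without moving the number beyond the scatter. The other step, a number 2 percentage points higher from compound 2 to compound 3 (within the scatter), changed a different ring and was also flat. The step expected is therefore a number 3 percentage points lower from compound 2 to compound 4 (within the scatter), that is, none beyond the scatter. Compound 4 is estimated to give 90%, in a range from 78% to 97%.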

Compound 4, a percentage reported as inhibition, at one concentration (the size of the read-out at that concentration, not a potency): 91%
Beside the measured number, compound 4's estimate is 1 percentage points below it; the range from low to high includes it.
By their numbers in this assay, from the lowest: compounds 1, 4, 2 and 3 (each within the scatter of the next).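

On the sulfonyl sulfur, this assay now shows that 3-fluoro-4-methylphenyl can stand in place of 3-chloro-4-fluorophenyl, with a number 2 percentage points lower from compound 2 to compound 4 (within the scatter) even though the chlorine is gone and a methyl has entered. Set against the simpler 4-fluorophenyl, the same group gives a number 1 percentage points higher from compound 1 to compound 4 (within the scatter) and so all three rings on this sulfur read level. No measured information accounts for this flat result.

Going by these compounds, whether the number stays level when this ring carries an amine or a carboxylic acid remains open. A single-concentration reading that sits this high for every compound also leaves any difference in potency among these rings unresolved.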